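Adding a methoxy group to the core of compound 1

The source may report more compounds than this note shows. Statements on the series, on what has been measured and on what is new or still open speak of the compounds shown alone.

Measured compounds: compound 1 `CC(C)c1ccc(-c2cc(=O)c3cc(C(=O)O)ccc3o2)cc1`, 19%; compound 2 `CCCCCCc1ccc(-c2cc(=O)c3cc(C(=O)O)ccc3o2)cc1`, 2%.

Going by the values given here, in a functional assay on the whole organism (stomach) for inhibition, with Rattus norvegicus as the target, at a dose of 80 mg/kg (a higher number here means more inhibition at the dose given (going by the name of the read-out), a lower number less inhibition), compound 1 stands highest of the two numbers; the only step to it runs a number 17 percentage points lower from compound 1 to compound 2 (beyond the scatter). Compound 3 `COc1c(-c2ccc(C(C)C)cc2)oc2ccc(C(=O)O)cc2c1=O` differs from compound 1 by methoxy in place of hydrogen on an aromatic carbon. No measured step touches the same place, since the one known step changes the group on the other ring instead, so nothing shown bears on this change. The expected step is therefore a number 4 percentage points lower from compound 1 to compound 3 (within the scatter), none beyond the scatter. Compound 3 is estimated at 15%, with a range from 0% to 35%.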

Compound 3, a percentage reported as inhibition, in the whole organism at one dose (the size of the read-out at that dose, not a potency): 18%
Estimate against measurement, compound 3: 3 percentage points below; low and high end bracket the measured number.
By their numbers in this assay, from the lowest: compound 2; then compounds 3 and 1 (each within the scatter of the next).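

In this assay, methoxy in place of hydrogen on this aromatic carbon of the core gives a number 1 percentage points lower from compound 1 to compound 3 (within the scatter), so compound 1 and compound 3 cannot be told apart. Going by these compounds alone, this is the first look at this position, and at this dose it accepts methoxy without a difference beyond the scatter. No available evidence accounts for this result.

On these data alone, whether a hydroxyl, an amine or a longer ethoxy group would read the same at this position remains open. So does the effect of methoxy here when the other ring carries hexyl, as in compound 2.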